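Bromo to iodo on the shared core

A few compounds are considered here, and "the series" means these few. Any claim that something is new, unique, unknown or untested is made for them only; others in the source may bear on it.

In a functional assay on A549 cells (Homo sapiens) for inhibition, read by MTT assay, with a stated time of 48 h (on this read-out lower numbers stand for stronger inhibition and higher numbers for weaker inhibition), compound 1 `O=C(CCCCCC(=O)NCc1ccc2cc(Cl)ccc2n1)NO` gives 2710 nM and compound 2 `O=C(CCCCCC(=O)NCc1ccc2cc(Br)ccc2n1)NO` gives 3890 nM. These two values cannot be ordered: a 1.4-fold higher number from compound 1 to compound 2 (0.16 log units; within the scatter), bromo in place of chloro on an aromatic carbon. Among the compounds with values here, compound 2 therefore stands level with its only measured neighbour.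

Compound 3 `O=C(CCCCCC(=O)NCc1ccc2cc(I)ccc2n1)NO` carries the next exchange: iodo in place of bromo on an aromatic carbon. Within the data shown here, the single measured halogen exchange, a 1.4-fold higher number from compound 1 to compound 2 (0.16 log units; within the scatter), stayed within the scatter, so no step beyond the scatter is expected in this assay. The expected step is a 1.0-fold higher number from compound 2 to compound 3 (0.01 log units; within the scatter). Compound 3 is estimated at 4000 nM, with an expected range of 2000 nM to 8000 nM.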

Compound 3, half-maximal inhibitory concentration: 2580 nM
The estimate for compound 3 lay 1.6-fold (0.19 log units) above the measured number; the range from low to high includes it.
By their numbers in this assay, from the lowest: compounds 3, 1 and 2 (each within the scatter of the next).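

With iodo on this aromatic carbon, this assay still separates none of the halogens: a 1.5-fold lower number from compound 2 to compound 3 (0.18 log units; within the scatter) and a 1.1-fold lower number from compound 1 to compound 3 (0.02 log units; within the scatter) both stay within the scatter. Chloro, bromo and iodo at this position therefore read level, and the series now holds three such exchanges rather than one, none beyond the scatter. Nothing available explains this flat reading.

Open, as far as these compounds go, is whether a non-halogen group at this position, such as an amine or a carboxylic acid, would give a step beyond the scatter. Also open, from the compounds shown here alone, is whether a longer chain on the shared core would do so.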